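This account rests on a few compounds, and the source may have more. Where it says the series, first, only, none or still open, it means among the compounds named here.

Measured so far in a functional assay on HepG2 cells (Homo sapiens) for cytotoxicity, read by sulforhodamine B assay, with a stated time of 48 h; on this read-out lower numbers stand for stronger inhibition and higher numbers for weaker inhibition:
compound 1, `C/C(=N\NC(=O)CC#N)c1ccc(NS(=O)(=O)c2ccc(Cl)cc2)cc1`, 8000 nM
compound 2, `CCOC(=O)c1c(/C=C/c2ccccc2)c(C#N)c(=O)n(/N=C(\C)c2ccc(NS(=O)(=O)c3ccc(Cl)cc3)cc2)c1N`, 10700 nM

In this assay compound 1 gives 8000 nM and compound 2 gives 10700 nM. For the measured compounds named here, compound 2 has compound 1 as its only neighbour, and the gap between the two numbers is within the scatter of repeated measurements, so the two compounds cannot be told apart on this read-out; both sit in the weak range.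

Compound 3, `CCOC(=O)c1c(-c2ccc(N(C)C)cc2)c(C#N)c(=O)n(/N=C(\C)c2ccc(NS(=O)(=O)c3ccc(Cl)cc3)cc2)c1N`, has not yet been measured. It differs from compound 2 in one place: 4-(dimethylamino)phenyl in place of 2-phenylethenyl on an aromatic carbon. Going by the values given here, no measured pair shows what such a change does in this assay, so there is no basis for expecting a step beyond the scatter in either direction. Among the compounds with values here, compound 3 is therefore estimated near compound 2 because compound 2 gives 10700 nM with no measured step to build on. The expected step from compound 2 to compound 3 is a 1.1-fold lower number from compound 2 to compound 3 (0.03 log units; within the scatter). The estimate for compound 3 is 10000 nM, with a range from 3500 nM to 30000 nM.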

Compound 3, half-maximal inhibitory concentration: 21000 nM
Estimate against measurement, compound 3: 2.1-fold (0.32 log units) below; the measured number falls inside the stated range.
By their numbers in this assay, from the lowest: compounds 1, 2 and 3 (each within the scatter of the next, the first and the last beyond it).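

At the aromatic carbon opposite the ring nitrogen, replacing 2-phenylethenyl with 4-(dimethylamino)phenyl gives a 2.0-fold higher number from compound 2 to compound 3 (0.29 log units; within the scatter) in this assay, and this step lies within the scatter, so compound 2 and compound 3 cannot be told apart. This position therefore accepts two different groups without a measurable change on this read-out: the entering group brings a nitrogen and a hydrogen-bond acceptor, the leaving group a double bond outside aromatic rings, and both carry a six-membered aromatic ring of carbon only. No available evidence bears on what lies behind this result.

Going by these compounds, both groups at this position are large and contain an aromatic ring, so the effect of a small group, such as a methyl or a free amine, remains open. On these data alone, whether a carboxylic acid or a simple alkyl chain here would move the number beyond the scatter also remains unknown.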